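Amino for chloro between two ring nitrogens on a benzyl-linked core

This account rests on a few compounds, and the source may have more. Where it says the series, first, only, none or still open, it means among the compounds named here.

Measured compounds:
compound 1 `ClCc1ccccc1Cn1cnc2c(Cl)nc(Cl)nc21` gives 380 nM
compound 2 `ClCc1ccccc1Cn1cnc2ncnc(Cl)c21` gives 4070 nM

Compound 1 and compound 2 were tested in a functional assay on HCT-116 cells (Homo sapiens) for cytotoxicity, read by sulforhodamine B assay, with a stated time of 48 h; a higher number here means a weaker inhibitor of growth, a lower number a stronger inhibitor of growth. Going by the values given here, of the two, compound 1 gives the lower number, and the gap to compound 2 lies beyond the usual scatter; the two structures differ in more than one place, so no single step is drawn between them. The next compound, compound 3 `Nc1nc(Cl)c2ncn(Cc3ccccc3CCl)c2n1`, is not yet measured in this assay. Compared with compound 1, the change is amino in place of chloro on an aromatic carbon, so that the ring carbon between two ring nitrogen atoms now carries an amino group while the chloro on the other ring carbon remains. Among the compounds with values here, with no measured step for an exchange of this kind, the step from compound 1 to compound 3 is expected to be modest and to run toward a higher number, a 2.1-fold higher number from compound 1 to compound 3 (0.32 log units; beyond the scatter), possibly within the scatter. Compound 3 is therefore estimated at 800 nM, with a range from 250 nM to 3000 nM.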

Compound 3, concentration for total growth inhibition: > 100000 nM
Compound 3 gave a limit, no number (the forecaster's own chance of this, stated with the estimate: 10%); middle value at least 120-fold (2.09 log units) away from the limit.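

In this assay, the ring carbon between two ring nitrogen atoms turns out not to tolerate every substituent, as amino in place of chloro there gives an at least 260-fold higher number from compound 1 to compound 3 (2.42 log units; beyond the scatter). Going by these compounds alone, this is the first single-place step, since compound 1 and compound 2 differ in more than one place and could not isolate this position. Compound 3 gives > 100000 nM, which is a limit of the assay and not a number, so the step has a known minimum but no known size: the limit of > 100000 nM in this assay, at which 1 of the 3 values shown sits.

As far as these compounds go, whether the loss of chloro or the arrival of amino drives this step remains open, and a methoxy, methylamino or fluoro group at this position could help separate the two. Also open, from the compounds shown here alone, is how the same exchange would read on the other ring carbon that carries chloro.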